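This account rests on a few compounds, and the source may have more. Where it says the series, first, only, none or still open, it means among the compounds named here.

Within the data shown here, in an ADME assay on NHDF cells (Homo sapiens) for cytotoxicity, read by MTT assay, with a stated time of 72 h (on this read-out lower numbers stand for stronger inhibition and higher numbers for weaker inhibition), compound 1 `COc1ccc(/C=C2\CCC/C(=C\c3ccccc3Cl)C2=O)cc1OC` gives 21600 nM and compound 2 `COc1ccc(/C=C2\CCC/C(=C\c3ccc(Br)cc3)C2=O)cc1OC` gives 13100 nM, so compound 2 stands within the scatter of the only other measured compound. Compound 3 `COc1ccc(/C=C2\CCC/C(=C\c3ccc(O)cc3)C2=O)cc1OC` has hydroxy in place of bromo on an aromatic carbon. Among the measured compounds shown here, one measured step bears on this, a 1.6-fold lower number from compound 1 to compound 2 (0.22 log units; within the scatter), and it also changed this aromatic group. For the measured compounds named here, no measured compound carries hydroxy, so this guide is weak. No step beyond the scatter is expected in this assay, and the estimated change is a 1.1-fold higher number from compound 2 to compound 3 (0.06 log units; within the scatter). For compound 3 the expected value is 15000 nM, with an estimated range of 6000 nM to 40000 nM.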

Compound 3, half-maximal inhibitory concentration: 26100 nM
Beside the measured number, compound 3's estimate is 1.7-fold (0.24 log units) below it; the range from low to high includes it.
By their numbers in this assay, from the lowest: compounds 2, 1 and 3 (each within the scatter of the next).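

In this assay, hydroxy in place of bromo gives a 2.0-fold higher number from compound 2 to compound 3 (0.30 log units; within the scatter), so adding the hydrogen-bond donor and acceptor that bromo lacks does not move the number beyond the scatter at this aromatic carbon. Changing 2-chlorophenyl to 4-hydroxyphenyl gives a 1.2-fold higher number from compound 1 to compound 3 (0.08 log units; within the scatter), so these three aromatic groups cannot be told apart here. No measurement shown offers a reason for this. Going by these compounds, whether an amine or a carboxylic acid on this aromatic carbon would give a step beyond the scatter stays open.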